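Carbamate selenocyanates: a propyl to isobutyl step

The source may hold more compounds than are shown below. What is called first, only, known or untested is meant among the compounds shown, and "the series" means these compounds.

Of the compounds shown here, three have numbers so far. Compound 1 `COc1ccc(OC(=O)Nc2ccc([Se]C#N)cc2)cc1` gives 25200 nM in an ADME assay on BEAS-2B cells (Homo sapiens) for cytotoxicity, read by MTT assay, with a stated time of 72 h (on this read-out lower numbers stand for stronger inhibition of growth and higher numbers for weaker inhibition of growth), compound 2 `CC(C)COC(=O)Nc1ccc([Se][Se]c2ccc(NC(=O)OCC(C)C)cc2)cc1` gives 13100 nM, and compound 3 `CCCOC(=O)Nc1ccc([Se]C#N)cc1` gives 19200 nM. The three numbers all fall within the scatter of one another, so compound 3 cannot be set apart from either neighbour. Compound 4 `CC(C)COC(=O)Nc1ccc([Se]C#N)cc1` has not been measured. It differs from compound 3 by methyl in place of hydrogen on a saturated chain carbon bound to two saturated chain carbons. Going by the values given here, no measured pair shows this kind of change, so nothing here points to a step beyond the scatter in either direction. For compound 4 the expected step is a 1.1-fold lower number from compound 3 to compound 4 (0.05 log units; within the scatter), amounting to about no change. Compound 4 is therefore estimated at 17000 nM, with a range from 8000 nM to 40000 nM.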

Compound 4, concentration for 50% growth inhibition: 26900 nM
Compound 4: the middle estimate sits 1.6-fold (0.20 log units) below what was measured, and the stated range covers the measured number.
By their numbers in this assay, from the lowest: compounds 2, 3, 1 and 4 (each within the scatter of the next, the first and the last beyond it).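

In this assay, going by these compounds alone, this pair gives the first direct reading of the change, with a 1.4-fold higher number from compound 3 to compound 4 (0.15 log units; within the scatter) as methyl replaces hydrogen on a saturated chain carbon bound to two saturated chain carbons. Going from propyl to isobutyl therefore gives no difference that can be told apart from repeat-measurement noise in these cells. No measurement here offers an explanation for this result. One pair cannot show whether the same holds for other chains. A longer chain such as hexyl, or an amine at this place, remains an open question.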